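The source may report more compounds than this note shows. Statements on the series, on what has been measured and on what is new or still open speak of the compounds shown alone.

Three compounds share one core, an indole carrying an aryl group and a vinyl sulfone bearing either a nitrile or an acetyl group, and each has been tested in a functional assay on Hs-578T cells (Homo sapiens) for inhibition, read by sulforhodamine B assay, with a stated time of 48 h; a lower number here means a stronger inhibitor of growth, a higher number a weaker inhibitor of growth. Compound 1 `COc1ccc(-c2[nH]c3ccccc3c2/C=C(\C#N)S(=O)(=O)c2ccccc2)cc1` gives 682 nM. Going by the values given here, compound 2 `COc1ccc(-c2[nH]c3ccc(OC)cc3c2/C=C(\C#N)S(=O)(=O)c2ccccc2)cc1` gives 538 nM; the only measured one-place step, a 1.3-fold lower number from compound 1 to compound 2 (0.10 log units; within the scatter), adds a methoxy group on the indole ring and stays within the scatter. Compound 3 `CC(=O)/C(=C\c1c(-c2ccccc2)[nH]c2ccccc12)S(=O)(=O)c1ccccc1` gives 5000 nM, a clearly weaker result, but it differs from compound 2 in more than one place, so no single step can be read from it.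

Compound 4 `COc1ccc2[nH]c(-c3ccccc3)c(/C=C(\C#N)S(=O)(=O)c3ccccc3)c2c1` differs from compound 2 by hydrogen in place of methoxy on an aromatic carbon. Among the compounds with values here, no measured step touches this aryl group directly; the one step that does exist removes or adds a methoxy elsewhere and changes little. On that basis the change is expected to be small in this assay, with no clear direction, and the step of a 1.2-fold higher number from compound 2 to compound 4 (0.08 log units; within the scatter) is expected to sit within the scatter. Compound 4 is therefore estimated at 650 nM, in a range from 300 nM to 1400 nM.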

Compound 4, concentration for 50% growth inhibition: 7600 nM
Estimate against measurement, compound 4: 12-fold (1.07 log units) below, outside the stated range (above it).
By their numbers in this assay, from the lowest: compounds 2 and 1 (each within the scatter of the next); then compounds 3 and 4 (each within the scatter of the next).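

In this assay, the step of a 14-fold higher number from compound 2 to compound 4 (1.15 log units; beyond the scatter) shows that the methoxy in 4-methoxyphenyl counts for a great deal: with phenyl in its place, growth inhibition becomes much weaker. Going by these compounds alone, the only earlier step, a 1.3-fold lower number from compound 1 to compound 2 (0.10 log units; within the scatter), added a methoxy at another place on the shared core and stayed within the scatter. The same group can therefore matter little at one place and a great deal at another, at least in these compounds. Nothing available here explains this large step.

The compounds shown leave open whether a hydroxyl group, an ethoxy group or an amine on the same aromatic carbon would keep the lower number. They also leave open whether this methoxy would count as much with an acetyl group in place of the nitrile.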